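The source may hold more compounds than are shown below. What is called first, only, known or untested is meant among the compounds shown, and "the series" means these compounds.

Compound 1 `CO[C@H](C)[C@H](N)CN(C(=O)[C@@H]1C[C@H]1c1ccccc1)c1ccc(-c2ccccc2)cc1` gives 0.68 nM in a functional assay for agonist activity at G protein-coupled receptor 88 (Homo sapiens), read by HTRF and cAMP accumulation; on this read-out lower numbers stand for an effect already at smaller amounts and higher numbers for an effect only at larger amounts of compound. Compound 2 `CC[C@H](C)[C@H](N)CN(C(=O)[C@@H]1C[C@H]1c1cccc(F)c1)c1ccc(-c2ccccc2)cc1` gives 560 nM in this assay. Compound 3 `CC[C@H](C)[C@H](N)CN(C(=O)[C@@H]1C[C@H]1C1CCCCC1)c1ccc(-c2ccccc2)cc1` stands apart: compound 3 gives > 25000 nM in this assay, and this is only a limit, not a number, namely (the limit of > 25000 nM in this assay, at which 1 of the 3 values shown sits).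

Compound 4 `CC[C@H](C)[C@H](N)CN(C(=O)[C@@H]1C[C@H]1c1cccs1)c1ccc(-c2ccccc2)cc1` has not yet been measured. It differs from compound 3 in one place: thiophen-2-yl in place of cyclohexyl on a saturated ring carbon. For the measured compounds named here, the only measured step that bears on this change is an at least 44-fold higher number from compound 2 to compound 3 (1.64 log units; beyond the scatter), in which an aromatic ring gave way to a saturated one; compound 4 reverses that kind of change, bringing back an aromatic ring. A large step in the other direction, beyond the scatter, is therefore expected, an at least 83-fold lower number from compound 3 to compound 4 (1.92 log units; beyond the scatter). Compound 4 is estimated to give about 300 nM in this assay, with a likely range from 50 nM to 3000 nM.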

Compound 4, half-maximal effective concentration: 360 nM
Estimate against measurement, compound 4: 1.2-fold (0.08 log units) below; the measured number falls inside the stated range.
By their numbers in this assay, from the lowest: compound 1; then compounds 4 and 2 (each within the scatter of the next). At a limit, above all of these: compound 3.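

In this assay, thiophen-2-yl on this saturated ring carbon restores a measurable effect, with an at least 69-fold lower number from compound 3 to compound 4 (1.84 log units; beyond the scatter). A five-membered aromatic ring with a sulfur atom and 3-fluorophenyl cannot be told apart at this place, with a 1.6-fold lower number from compound 2 to compound 4 (0.19 log units; within the scatter). Compounds 2 and 4 thus share an aromatic ring here, while compound 3, with cyclohexyl, stands only at a limit: the limit of > 25000 nM in this assay, at which 1 of the 4 values shown sits.

For the compounds shown here, compound 1 differs from compounds 2, 3 and 4 in more than one place, so no step to it can be read. Open remain pyridin-2-yl and thiophen-3-yl at this place, and whether a smaller saturated ring such as cyclopentyl behaves like cyclohexyl.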